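This account rests on a few compounds, and the source may have more. Where it says the series, first, only, none or still open, it means among the compounds named here.

Compound 1, `COc1ccccc1NC(=O)CN(c1cc(Cl)ccc1OC)S(=O)(=O)c1ccccc1`: 15500 nM
Compound 2, `COc1ccc(NC(=O)CN(c2cc(Cl)ccc2OC)S(=O)(=O)c2ccccc2)cc1OC`: > 20000 nM (a limit)
Compound 3, `COc1ccc(Cl)cc1N(CC(=O)Nc1ccc(Cl)cc1)S(=O)(=O)c1ccccc1`: > 20000 nM (a limit)

Among the compounds with values here, in a functional assay on SH-SY5Y cells (Homo sapiens), read by MTT assay, with a stated time of 24 h (on this read-out higher numbers stand for an effect only at larger amounts of compound and lower numbers for an effect already at smaller amounts), compound 1 gives 15500 nM, the only number in the set. For compound 2 the value > 20000 nM is a limit of the assay and not a number. For compound 3 the value > 20000 nM is likewise a limit. Compound 4, `COc1ccc(NC(=O)CN(c2cc(Cl)ccc2OC)S(=O)(=O)c2ccccc2)cc1`, differs from compound 1 by 4-methoxyphenyl in place of 2-methoxyphenyl on an amide-type nitrogen. Two measured steps also change the group on the amide-type nitrogen: an at least 1.2-fold higher number from compound 1 to compound 2 (0.11 log units; that floor lies within the scatter) and an at least 1.2-fold higher number from compound 1 to compound 3 (0.11 log units; that floor lies within the scatter); both end at the limit of > 20000 nM in this assay, at which 2 of the 3 values shown sit. A move to a higher number, or again to the limit, is therefore expected for compound 4, though its size cannot be read from these steps. The estimate for compound 4 is 22000 nM, with a range from 10000 nM to 50000 nM, meaning an expected 1.4-fold higher number from compound 1 to compound 4 (0.15 log units; within the scatter).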

Compound 4, half-maximal effective concentration: 16200 nM
Compound 4: the middle estimate sits 1.4-fold (0.13 log units) above what was measured; the range from low to high includes it.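

In this assay, within the data shown here, 4-methoxyphenyl in place of 2-methoxyphenyl on an amide-type nitrogen gives a 1.0-fold higher number from compound 1 to compound 4 (0.02 log units; within the scatter), the first pair where both values are numbers. Moving the methoxy within this group therefore leaves the read-out within the scatter. The steps from the two limit compounds, an at least 1.2-fold lower number from compound 3 to compound 4 (0.09 log units; that floor lies within the scatter) and an at least 1.2-fold lower number from compound 2 to compound 4 (0.09 log units; that floor lies within the scatter), have floors within the scatter, so neither methoxy for chloro nor hydrogen for methoxy is shown to matter.

Open, going by these compounds, is whether an amine or a carboxylic acid in place of methoxy on that aromatic carbon would shift the number beyond the scatter.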